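Sulfonylphenoxy Arm Replaces Alkyl Sulfone on Shared Core

The source may hold more compounds than are shown below. What is called first, only, known or untested is meant among the compounds shown, and "the series" means these compounds.

Compound 1 `Cn1c(-c2ccccc2C(F)(F)F)nnc1C12CCC(CCS(C)(=O)=O)(CC1)CC2`: in an assay on CHO-K1 cells for inhibition of 11-beta-hydroxysteroid dehydrogenase type 2 (Homo sapiens), read by scintillation proximity assay (on this read-out lower numbers stand for stronger inhibition and higher numbers for weaker inhibition), compound 1 gives > 4000 nM, which is a limit of the assay rather than a number.
Compound 2 `Cn1c(-c2ccccc2C(F)(F)F)nnc1C12CCC(CCCC(C)(F)F)(CC1)CC2`: in this assay compound 2 gives > 4000 nM, again a limit.
Compound 3 `CC(C)S(=O)(=O)CCC12CCC(c3nnc(-c4ccccc4C(F)(F)F)n3C)(CC1)CC2`: in this assay compound 3 gives > 4000 nM, also a limit.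

Compound 3 therefore stands at the limit of > 4000 nM in this assay, at which 3 of the 3 values shown sit, and nothing in the numbers places it above or below the other two. The step that the two limits leave unreadable from compound 1 to compound 3 and the step that the two limits leave unreadable from compound 2 to compound 3 are both unreadable, as is a step that the two limits leave unreadable from compound 1 to compound 2. Every value involved is a limit and not a measurement.

Compound 4 `Cn1c(-c2ccccc2C(F)(F)F)nnc1C12CCC(COc3ccc(S(C)(=O)=O)cc3)(CC1)CC2` differs from compound 3 in one place: 4-(methylsulfonyl)phenoxy in place of (isopropylsulfonyl)methyl on a saturated chain carbon bound to a saturated ring carbon. The entering group brings an aromatic ring and a further oxygen into the side chain where compound 3 carries only a short saturated arm.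

Within the data shown here, none of the measured steps can be read, so no size or direction can be carried over to this change; the only guidance is that three side-chain variants on the same core all remain at the limit. On that basis compound 4 is expected to give about 5000 nM in this assay, within a wide range from 800 nM to 30000 nM. The corresponding expected step is a step that the limit leaves unreadable from compound 3 to compound 4, with a real chance that compound 4 is again reported only as a limit.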

Compound 4, half-maximal inhibitory concentration: > 4000 nM
Compound 4: a limit, no number; the forecaster's own chance of this, stated with the estimate: 60%; the middle value does not contradict the limit.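

The result for compound 4 in this assay is a limit, so its steps from compound 1, compound 2 and compound 3 cannot be read, and the whole set sits at one reading: the limit of > 4000 nM in this assay, at which 4 of the 4 values shown sit. The compounds shown leave open how strongly any of these side chains on the shared core inhibits the enzyme, and whether they differ at all.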